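Swapping one ester group on a shared core

The compounds below may be only part of what the source reports. "The series", "measured", "known", "first", "only" and "open" are said of these compounds alone.

Compound 1 (`C=C1CC[C@@H]2[C@](C)(COC(=O)CCCCC3CCSS3)[C@H](OC(=O)CCCCC3CCSS3)CC[C@@]2(C)[C@@H]1/C=C/C1=CCOC1=O`) gives 10200 nM
Compound 2 (`C=C1CC[C@@H]2[C@](C)(COC(=O)C3CCCN3C(=O)OC(C)(C)C)[C@H](O)CC[C@@]2(C)[C@@H]1/C=C/C1=CCOC1=O`) gives 18800 nM

Both numbers come from a functional assay on A549 cells (Homo sapiens) for inhibition, read by sulforhodamine B assay, with a stated time of 72 h (on this read-out lower numbers stand for stronger inhibition of growth and higher numbers for weaker inhibition of growth), and lie within the usual scatter of each other, so compound 2 stands level with compound 1 on the evidence so far. Compound 3 (`C=C1CC[C@@H]2[C@](C)(COC(=O)CCCCC3CCSS3)[C@H](O)CC[C@@]2(C)[C@@H]1/C=C/C1=CCOC1=O`) is not yet measured. The change from compound 2 to compound 3 takes place on a carbonyl carbon, where the 1-(tert-butoxycarbonyl)pyrrolidin-2-yl group leaves: a group of 9 heavy atoms (7 carbon, 2 sulfur; one five-membered non-aromatic ring with 2 hetero atoms) in place of a group of 12 heavy atoms (9 carbon, 1 nitrogen, 2 oxygen; one five-membered non-aromatic ring with 1 hetero atom), on a carbonyl carbon is the counted difference. For the measured compounds named here, no measured pair shows this change on its own, so its effect in this assay can only be estimated. Going by the values given here, with compound 2 at 18800 nM as the starting point and compound 1 at 10200 nM as the only other guide, no step beyond the scatter is expected. The estimated size is a 1.3-fold lower number from compound 2 to compound 3 (0.13 log units; within the scatter) and no more than that. For compound 3 the estimated value is 14000 nM with an expected range from 6000 nM to 32000 nM in this test.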

Compound 3, concentration for 50% growth inhibition: > 30000 nM
Compound 3 was reported as a limit (the forecaster's own chance of this, stated with the estimate: 10%); middle value at least 2.1-fold (0.33 log units) from the limit.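

Compound 3 can be read only as a limit in this assay: the limit of > 30000 nM in this assay, at which 1 of the 3 values shown sits.

Exchanging the 1-(tert-butoxycarbonyl)pyrrolidin-2-yl group for the group with the sulfur-containing ring gives an at least 1.5-fold higher number from compound 2 to compound 3 (0.20 log units; that floor lies within the scatter), so this floor alone does not separate the two esters. The clearer result comes from a hydrogen atom replacing the group of 11 heavy atoms on an oxygen on a saturated carbon, which gives an at least 2.9-fold higher number from compound 1 to compound 3 (0.46 log units; beyond the scatter), showing that this second ester position matters for growth inhibition in this pair.

On these data alone, how far compound 3 lies past its limit stays unknown, so both steps are only floors. As far as these compounds go, it also remains open whether a smaller acetyl group or a longer carbon chain on that oxygen would give the same reading as the group in compound 1.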